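The source may report more compounds than this note shows. Statements on the series, on what has been measured and on what is new or still open speak of the compounds shown alone.

Three compounds share one core: compound 1 `CC(C)(C)c1ccc(S(=O)(=O)Nc2ccccc2O)cc1`, compound 2 `CC(C)(C)c1ccc(S(=O)(=O)Nc2ccc(O)cc2)cc1` and compound 3 `Cc1ccc(NS(=O)(=O)c2ccc(C(C)(C)C)cc2)cc1`. In a functional assay on A549 cells (Homo sapiens) for inhibition (a higher number here means a weaker inhibitor of growth, a lower number a stronger inhibitor of growth), compound 1 gives 13000 nM, compound 2 gives 14000 nM and compound 3 gives 11000 nM. Compound 3 therefore stands level with the other two, and neither of its gaps goes beyond the scatter.

The next compound, compound 4 `Cc1ccc(NS(=O)(=O)c2ccc(C(C)(C)C)cc2)c(O)c1`, keeps all of compound 3 and adds one group: hydroxy in place of hydrogen on an aromatic carbon. For the measured compounds named here, three measured steps bear on this change. Between the two compounds that carry hydroxy, the step is a 1.1-fold higher number from compound 1 to compound 2 (0.03 log units; within the scatter). Methyl in place of the hydroxy-bearing arrangement gives a 1.2-fold lower number from compound 1 to compound 3 (0.07 log units; within the scatter) and a 1.3-fold lower number from compound 2 to compound 3 (0.10 log units; within the scatter). All three lie within the scatter. Going by the values given here, none of them compares hydroxy with hydrogen directly, and the data hold no measured example of adding a hydroxy to a ring that already carries methyl. Even so, nothing in this small set points to a real shift, so no step beyond the scatter is expected in this assay. The expected size is no change at the digits printed from compound 3 to compound 4 (within the scatter). For compound 4 the estimated value is 11000 nM, with an expected range from 6000 nM to 20000 nM.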

Compound 4, concentration for 50% growth inhibition: 8000 nM
Compound 4: middle estimate off by 1.4-fold (0.14 log units), on the high side; low and high end bracket the measured number.
By their numbers in this assay, from the lowest: compounds 4, 3, 1 and 2 (each within the scatter of the next).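

In this assay, for the compounds shown here, hydroxy in place of hydrogen, on an aromatic carbon ortho to a large group and meta to a methyl group, gives a 1.4-fold lower number from compound 3 to compound 4 (0.14 log units; within the scatter); this is the only direct comparison of hydroxy with hydrogen in the set, and it shows that adding the group to a ring that already carries methyl produces no step beyond the scatter. Going by these compounds alone, compound 4 also supplies the only measured change of methyl in place of hydrogen on a ring that already carries hydroxy, with a 1.6-fold lower number from compound 1 to compound 4 (0.21 log units; within the scatter), so having both groups on the ring leaves compound 4 within the scatter of each compound that carries only one of them. The data offer no explanation for either step.

The compounds shown leave open whether an amine or a carboxylic acid on this same aromatic carbon would give a step beyond the scatter, and whether a longer chain in place of the methyl would do so. Going by these compounds, whether the hydroxy change would read the same way in any other cell line also remains open.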